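A few compounds are considered here, and "the series" means these few. Any claim that something is new, unique, unknown or untested is made for them only; others in the source may bear on it.

In an assay on isolated protein (Oryctolagus cuniculus) with Thromboxane-A synthase (Homo sapiens) as the target, tested at 1 uM (on this read-out higher numbers stand for more inhibition at the one concentration tested (going by the name of the read-out) and lower numbers for less inhibition), compound 1 `CC(C)n1nc(-c2cccnc2)c2ccccc2c1=O` gives 87%, the highest of the three numbers shown. Compound 3 `O=c1c2ccccc2c(-c2cccnc2)nn1CCSc1ncccn1` gives 86% in this assay, a number within the scatter of that of compound 1, so the two cannot be ordered. Compound 2 `CCOC(=O)Cn1nc(-c2cccnc2)c2ccccc2c1=O` gives 28%, and the step of a number 59 percentage points lower from compound 1 to compound 2 (beyond the scatter) shows how much one exchange on the aromatic nitrogen can cost; the step of a number 58 percentage points higher from compound 2 to compound 3 (beyond the scatter) shows the same ground regained with another exchange at that position.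

Compound 4 `NCCn1nc(-c2cccnc2)c2ccccc2c1=O` differs from compound 1 in one place: 2-aminoethyl in place of isopropyl on an aromatic nitrogen. Both measured steps bear on it, since each also alters the group on that aromatic nitrogen, and each was large. They do not agree in direction, however: an ester-bearing chain loses much, while a longer chain ending in a ring loses nothing. The 2-aminoethyl chain resembles neither closely, so a step in this assay from compound 1 to compound 4 is expected to be downward, but of uncertain size, and is estimated at a number 32 percentage points lower from compound 1 to compound 4 (beyond the scatter). Compound 4 is therefore expected to give about 55% in this assay, within a range from 20% to 88%.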

Compound 4, a percentage reported as inhibition, at one concentration (the size of the read-out at that concentration, not a potency): 29%
Compound 4: middle estimate off by 26 percentage points, on the high side; the range from low to high includes it.
By their numbers in this assay, from the lowest: compounds 2 and 4 (each within the scatter of the next); then compounds 3 and 1 (each within the scatter of the next).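

In this assay, a number 58 percentage points lower from compound 1 to compound 4 (beyond the scatter) comes with 2-aminoethyl in place of isopropyl, although both groups hold 3 heavy atoms, so a large loss at this aromatic nitrogen occurs here with no change in that count, only one carbon exchanged for nitrogen and one hydrogen-bond donor and one acceptor added. The chain on that nitrogen does not by itself keep the number high: with amino in place of (pyrimidin-2-yl)sulfanyl, the result is a number 57 percentage points lower from compound 3 to compound 4 (beyond the scatter), so the group at the end of the chain matters as much as the chain. Among the compounds shown here, with aminomethyl in place of ethoxycarbonyl on the chain carbon bound to the aromatic nitrogen, a number 1 percentage points higher from compound 2 to compound 4 (within the scatter) shows that these two quite different groups cannot be told apart in this assay, which makes the ester no longer the only kind of group seen to go with a low number.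

Nothing available here says why either group goes with the low numbers. On these data alone, it remains open whether a dimethylamino group at the chain end, a carboxylic acid on the chain, a longer chain ending in an amine, or a plain ethyl or propyl group would stay near compound 4 or near compound 1.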